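Swapping Chloro for Fluoro on the Aryl Ring

The source may hold more compounds than are shown below. What is called first, only, known or untested is meant among the compounds shown, and "the series" means these compounds.

Compound 1 `Cc1cc(C2CS(=O)(=O)Oc3c2c(C2CC2)nn3-c2ccccc2Cl)ccc1Br` was studied in a physicochemical assay for lipophilicity, using the shake flask method, in phosphate buffer, measured as octanol-water partition, with a stated time of 24 h, at pH 7.4 (on this read-out lower numbers stand for lower lipophilicity and higher numbers for higher lipophilicity), where compound 1 gives 2.53. Two companions sit close to it: compound 2 `COc1ccc(-c2nn(-c3ccccc3F)c3c2CCS(=O)(=O)O3)cc1` gives 2.62, and compound 3 `O=S1(=O)CC(c2cccc(C(F)(F)F)c2)c2c(C3CC3)nn(-c3cccc(F)c3)c2O1` gives 2.73. Both gaps to compound 1 fall within the usual scatter of repeated measurements, so the three cannot be told apart on this read-out. Compound 4 `Cc1cc(C2CS(=O)(=O)Oc3c2c(C2CC2)nn3-c2ccccc2F)ccc1Br` is not yet measured; it differs from compound 1 by fluoro in place of chloro on an aromatic carbon. Within the data shown here, no measured pair in this set shows that same exchange, so the expectation rests on the change itself. A modest drop in this assay is expected, with the step from compound 1 to compound 4 estimated at a number 0.48 log units lower from compound 1 to compound 4 (beyond the scatter). Compound 4 is therefore expected to give about 2.05, somewhere between 1.7 and 2.4.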

Compound 4, partition coefficient: 2.72
Beside the measured number, compound 4's estimate is 0.67 log units below it; measured number above the stated range.
By their numbers in this assay, from the lowest: compounds 1, 2, 4 and 3 (each within the scatter of the next).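

Among these compounds, this pair gives the first direct reading of fluoro in place of chloro on this aromatic carbon, ortho to a large group: in this assay, the step is a number 0.19 log units higher from compound 1 to compound 4 (within the scatter) on an otherwise unchanged structure. At this position, then, the exchange leaves the two compounds indistinguishable on this read-out. No available evidence bears on why.

Still open, on these data alone, is whether an amine or a carboxylic acid at this position would shift the read-out beyond the scatter. As far as these compounds go, whether the same exchange behaves alike on other cores also remains unknown.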